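Aryl swap on the shared core: expectation for compound 3

A few compounds are considered here, and "the series" means these few. Any claim that something is new, unique, unknown or untested is made for them only; others in the source may bear on it.

Compound 2 `Cc1nc2c3ccccc3ccc2c2nc3c(ccc4ccccc43)c(-c3cc([N+](=O)[O-])ccc3N)c12` holds the lowest of the two numbers in hand: in a functional assay on HCT-116 cells (Homo sapiens) for cytotoxicity, read by MTT assay, with a stated time of 48 h (a lower number here means a stronger inhibitor, a higher number a weaker inhibitor), compound 2 gives 6010 nM. Compound 1 `Cc1nc2c3ccccc3ccc2c2nc3c(ccc4ccccc43)c(-c3cccc4ccccc34)c12` in this assay gives 20800 nM. Compound 3 `Cc1nc2c3ccccc3ccc2c2nc3c(ccc4ccccc43)c(-c3ccccc3Cl)c12` carries the change (2-chlorophenyl in place of 2-amino-5-nitrophenyl on an aromatic carbon). Going by the values given here, no measured step matches this swap; the only step at the same aromatic carbon is a 3.5-fold lower number from compound 1 to compound 2 (0.54 log units; beyond the scatter), which suggests the 2-amino-5-nitrophenyl itself carries the lower number. A partial return toward compound 1 is therefore expected, estimated as a 2.0-fold higher number from compound 2 to compound 3 (0.30 log units; within the scatter). For compound 3 in this assay the estimate is 12000 nM, within 4000 nM to 35000 nM.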

Compound 3, half-maximal inhibitory concentration: 48200 nM
Compound 3: middle estimate off by 4.0-fold (0.60 log units), on the low side; measured number outside the range, above it.
By their numbers in this assay, from the lowest: compound 2; then compound 1; then compound 3.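

In this assay 2-chlorophenyl in place of 2-amino-5-nitrophenyl gives an 8.0-fold higher number from compound 2 to compound 3 (0.90 log units; beyond the scatter) and 2-chlorophenyl in place of naphthalen-1-yl gives a 2.3-fold higher number from compound 1 to compound 3 (0.36 log units; beyond the scatter) at the same aromatic carbon. This position therefore moves the number up as well as down, and 2-chlorophenyl does not fall between the other two aryl groups. Nothing on hand accounts for this order.

On these data alone, whether the amino or the nitro group of 2-amino-5-nitrophenyl goes with the lowest number stays open. A plain phenyl, or a phenyl carrying only an amine or only a nitro group, would separate the two.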